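Thiourea sulfonamides: a dimethoxypyrimidinyl step on the nitrogen

A few compounds are considered here, and "the series" means these few. Any claim that something is new, unique, unknown or untested is made for them only; others in the source may bear on it.

Three compounds share a thiourea core and differ only at the sulfonamide nitrogen. Compound 1 `NS(=O)(=O)c1ccc(N/C(S)=N\c2ccnc3cc(C(F)(F)F)ccc23)cc1` carries hydrogen there and gives 52200 nM in a functional assay on HepG2 cells (Homo sapiens) for antiproliferative activity, read by sulforhodamine B assay, with a stated time of 48 h; on this read-out lower numbers stand for stronger inhibition and higher numbers for weaker inhibition. Compound 2 `CC(=O)NS(=O)(=O)c1ccc(N/C(S)=N\c2ccnc3cc(C(F)(F)F)ccc23)cc1` gives 28400 nM, and compound 3 `O=S(=O)(Nc1ncccn1)c1ccc(N/C(S)=N\c2ccnc3cc(C(F)(F)F)ccc23)cc1` gives 42100 nM. All three numbers lie within the scatter of one another, since a 1.8-fold lower number from compound 1 to compound 2 (0.26 log units; within the scatter), a 1.2-fold lower number from compound 1 to compound 3 (0.09 log units; within the scatter) and a 1.5-fold higher number from compound 2 to compound 3 (0.17 log units; within the scatter). Compound 4 `COc1ncnc(NS(=O)(=O)c2ccc(N/C(S)=N\c3ccnc4cc(C(F)(F)F)ccc34)cc2)c1OC` differs from compound 3 in one place: 5,6-dimethoxypyrimidin-4-yl in place of pyrimidin-2-yl on a sulfonamide nitrogen. The steps on this nitrogen, a 1.2-fold lower number from compound 1 to compound 3 (0.09 log units; within the scatter) and a 1.5-fold higher number from compound 2 to compound 3 (0.17 log units; within the scatter), stayed within the scatter, so no change beyond it is expected here; the step of a 1.1-fold lower number from compound 3 to compound 4 (0.02 log units; within the scatter) is an estimate of that size. Compound 4 is therefore expected at 40000 nM, with a range from 15000 nM to 110000 nM.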

Compound 4, half-maximal inhibitory concentration: 77300 nM
Estimate against measurement, compound 4: 1.9-fold (0.29 log units) below; low and high end bracket the measured number.
By their numbers in this assay, from the lowest: compounds 2, 3, 1 and 4 (each within the scatter of the next, the first and the last beyond it).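

In this assay, the sulfonamide nitrogen now shows a step beyond the scatter, though a modest one, with 5,6-dimethoxypyrimidin-4-yl in place of acetyl (a 2.7-fold higher number from compound 2 to compound 4 (0.43 log units; beyond the scatter)). Within the data shown here, the other two steps to this group stay within the scatter (a 1.8-fold higher number from compound 3 to compound 4 (0.26 log units; within the scatter)) and (a 1.5-fold higher number from compound 1 to compound 4 (0.17 log units; within the scatter)), so only the pair with acetyl separates. Nothing available here explains this step. The compounds shown leave open whether a carboxylic acid or an amine on a longer chain at this nitrogen would move the number further in either direction.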